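Swapping Methoxy for Isopropyl on the Phenyl Ring

This account rests on a few compounds, and the source may have more. Where it says the series, first, only, none or still open, it means among the compounds named here.

Compound 1, `CC#CC(CC(=O)O)c1ccc(OCc2ccn3cc(-c4ccc(C)cc4C)nc3c2)cc1`: 503 nM in an assay on isolated protein for agonist activity at Free fatty acid receptor 1 (Homo sapiens); on this read-out higher numbers stand for an effect only at larger amounts of compound and lower numbers for an effect already at smaller amounts.
Compound 2, `CC#CC(CC(=O)O)c1ccc(OCc2ccc3nc(-c4ccccc4C)cn3c2)cc1`: 389 nM in this assay.
Compound 3, `CC#CC(CC(=O)O)c1ccc(OCc2ccc3nc(-c4ccc(OC)cc4)cn3c2)cc1`: 47 nM in this assay.

Among these three, compound 3 stands lowest, with an 8.3-fold lower number from compound 2 to compound 3 (0.92 log units; beyond the scatter) separating it from compound 2, and compound 1 lying further still. Compound 4, `CC#CC(CC(=O)O)c1ccc(OCc2ccc3nc(-c4ccc(C(C)C)cc4)cn3c2)cc1`, differs from compound 3 in one place: isopropyl in place of methoxy on an aromatic carbon. Going by the values given here, no measured step matches this change. Among the compounds with values here, the only step available, an 8.3-fold lower number from compound 2 to compound 3 (0.92 log units; beyond the scatter), alters both the group and where it sits on the phenyl ring at once, so it does not show how methoxy and isopropyl compare at the same place. The expectation for compound 4 is therefore a change no larger than the scatter, a 1.7-fold higher number from compound 3 to compound 4 (0.23 log units; within the scatter). Compound 4 is estimated at 80 nM, with a range from 25 nM to 250 nM.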

Compound 4, half-maximal effective concentration: 528 nM
The estimate for compound 4 lay 6.6-fold (0.82 log units) below the measured number, and the stated range ends below it.
By their numbers in this assay, from the lowest: compound 3; then compounds 2, 1 and 4 (each within the scatter of the next).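

Methoxy and isopropyl can now be compared at the same place on the phenyl ring, and the choice between them clearly matters in this assay (an 11-fold higher number from compound 3 to compound 4 (1.05 log units; beyond the scatter)). Compound 4 does not separate from compound 2, despite the different group and position on the phenyl ring (a 1.4-fold higher number from compound 2 to compound 4 (0.13 log units; within the scatter)). No available evidence explains the gap between methoxy and isopropyl. Still open, from the compounds shown here alone, is how other groups at this place, such as an amine, a hydroxyl or a longer ether chain, would compare with methoxy. Going by these compounds, whether the same swap has a similar effect on the core of compound 1 is also open.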